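Spiro-piperidine ureas: alkyl replaces serine-derived substituent

The source may report more compounds than this note shows. Statements on the series, on what has been measured and on what is new or still open speak of the compounds shown alone.

Measured so far in an assay on HEK293 cells for inhibition of Voltage-dependent T-type calcium channel subunit alpha-1H (Homo sapiens), read by patch clamp, using a membrane potential dye; a lower number here means a stronger inhibitor, a higher number a weaker inhibitor:
compound 1 `CN1CC2(CCN(C(=O)Nc3cc(F)cc(F)c3)CC2)C1c1ccc(F)cc1` gives 410 nM
compound 2 `COC(=O)[C@H](COC(C)(C)C)NC(=O)N1CCC2(CC1)C(=O)N(c1cccc(F)c1)C2c1ccc(Cl)cc1` gives 251 nM
compound 3 `COC(=O)[C@H](CO)NC(=O)N1CCC2(CC1)C(=O)N(c1cccc(F)c1)C2c1ccc(Cl)cc1` gives 3330 nM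

Compound 3 stands at the highest number of the three in this assay. For the measured compounds named here, compound 2 and compound 3 share the whole core and differ only at the oxygen on the saturated carbon; the step of a 13-fold higher number from compound 2 to compound 3 (1.12 log units; beyond the scatter) is the only measured step in the set and it goes to a weaker inhibitor. Compound 1 has a different core and its number in this assay is well below that of compound 3.

Compound 4 `CCC(C)NC(=O)N1CCC2(CC1)C(=O)N(c1cccc(F)c1)C2c1ccc(Cl)cc1` carries the change (sec-butyl in place of 2-hydroxy-1-(methoxycarbonyl)ethyl on an amide-type nitrogen). Going by the values given here, no measured step covers this exchange. Among the compounds with values here, the one measured step shows that removing a hydrocarbon group from this region gave a large rise; the exchange into compound 4 removes the hydroxyl and ester entirely and puts a hydrocarbon chain in their place, so a fall in the number is expected rather than a rise, while its size is uncertain. For compound 4 the expected step is an 8.3-fold lower number from compound 3 to compound 4 (0.92 log units; beyond the scatter), placing compound 4 at an estimated 400 nM within 120 nM to 1500 nM.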

Compound 4, half-maximal inhibitory concentration: 1250 nM
Beside the measured number, compound 4's estimate is 3.1-fold (0.49 log units) below it, and the stated range covers the measured number.
By their numbers in this assay, from the lowest: compounds 2 and 1 (each within the scatter of the next); then compound 4; then compound 3.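

In this assay, the amide-type nitrogen keeps inhibition with a bare hydrocarbon on it: sec-butyl in place of 2-hydroxy-1-(methoxycarbonyl)ethyl gives a 2.7-fold lower number from compound 3 to compound 4 (0.43 log units; beyond the scatter), so neither the hydroxyl nor the ester is needed at this position. Hydrocarbon alone does not match the larger substituent, however: sec-butyl in place of 1-(methoxycarbonyl)-2-(tert-butoxy)ethyl gives a 5.0-fold higher number from compound 2 to compound 4 (0.70 log units; beyond the scatter), so the best number at this position still belongs to the group that carries both the ester and the tert-butyl ether. No measurement bears on the reason for either step.

It remains open which part of the 1-(methoxycarbonyl)-2-(tert-butoxy)ethyl group accounts for its lower number, the ester or the tert-butyl ether. Also open, going by these compounds, is how a longer alkyl chain, a benzyl group or a carboxylic acid in place of the methyl ester would read here.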